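A few compounds are considered here, and "the series" means these few. Any claim that something is new, unique, unknown or untested is made for them only; others in the source may bear on it.

The measured compounds are: compound 1, `CCCn1nc(-c2cccnc2)c2ccccc2c1=O`, which in an assay on isolated protein (Oryctolagus cuniculus) with Thromboxane-A synthase (Homo sapiens) as the target, tested at 1 uM (a lower number here means less inhibition, a higher number more inhibition at the concentration tested (going by the name of the read-out)), gives 86%; and compound 2, `C=CCn1nc(-c2cccnc2)c2ccccc2c1=O`, which in this assay gives 70%.

Within the data shown here, compound 2 stands as the lower of the two numbers; the single measured step is a number 16 percentage points lower from compound 1 to compound 2 (beyond the scatter).

Compound 3, `CCOC(=O)Cn1nc(-c2cccnc2)c2ccccc2c1=O`, differs from compound 2 by ethoxycarbonyl in place of vinyl on a saturated chain carbon bound to an aromatic nitrogen. Among the measured compounds shown here, only that one measured step bears on the new change, and it does so loosely: it altered the same saturated chain carbon bound to an aromatic nitrogen, but there vinyl replaced ethyl, whereas here ethoxycarbonyl replaces vinyl. For the measured compounds named here, no measured compound carries a carbonyl or an oxygen at this place, so nothing shows how such a group affects the read-out. A step of roughly the modest size seen between compound 1 and compound 2 is therefore expected in this assay, with its direction uncertain and no firm ground to expect it to pass beyond the scatter. Compound 3 is estimated at 65%, within 45% to 85%. That estimate corresponds to the expected step of a number 5 percentage points lower from compound 2 to compound 3 (within the scatter).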

Compound 3, a percentage reported as inhibition, at one concentration (the size of the read-out at that concentration, not a potency): 28%
Estimate against measurement, compound 3: 37 percentage points above; the measured number lies below the stated range.
By their numbers in this assay, from the lowest: compound 3; then compound 2; then compound 1.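

In this assay, this saturated chain carbon bound to an aromatic nitrogen proves far more sensitive than the first pair suggested: ethoxycarbonyl in place of vinyl gives a number 42 percentage points lower from compound 2 to compound 3 (beyond the scatter) and ethoxycarbonyl in place of ethyl gives a number 58 percentage points lower from compound 1 to compound 3 (beyond the scatter) on the same core. Both steps are large, whereas vinyl in place of ethyl gave only a modest step (a number 16 percentage points lower from compound 1 to compound 2 (beyond the scatter)), so the two ends made only of carbon and hydrogen stay well apart from the one carrying a carbonyl and two oxygen atoms. Nothing at hand accounts for the size of this loss.

The three compounds do not separate the part played by the carbonyl from that of the ethoxy end or of the larger number of heavy atoms in ethoxycarbonyl, and a plain longer chain such as butyl would be needed to set chain length apart from the oxygen atoms. From the compounds shown here alone, how a carboxylic acid, an amide or an amine would read at this place also remains open, as does whether the same change would carry the same weight on a different core.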